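The source may report more compounds than this note shows. Statements on the series, on what has been measured and on what is new or still open speak of the compounds shown alone.

Measured compounds:
- compound 1 `Cc1cc(O)cc(-c2nn(CC#N)cc2-c2ccnc(-c3ccc(Oc4ccccc4)cc3)c2)c1`: in a functional assay on M14 cells (Homo sapiens) for inhibition, read by sulforhodamine B assay, with a stated time of 48 h (on this read-out higher numbers stand for weaker inhibition of growth and lower numbers for stronger inhibition of growth), compound 1 gives 1700 nM
- compound 2 `COc1cc(C)cc(-c2nn(CC#N)cc2-c2ccnc(-c3ccc(N(C)C)cc3)c2)c1`: in this assay compound 2 gives 258 nM

Of the two numbers in hand, compound 2 carries the lower one; the gap to compound 1 lies beyond the scatter, so compound 2 is the stronger inhibitor of growth of the two. Going by the values given here, compound 1 and compound 2 differ in more than one place, so no single step between measured compounds can be read from them.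

Compound 3 `Cc1cc(O)cc(-c2nn(CC#N)cc2-c2ccnc(-c3ccc(N(C)C)cc3)c2)c1` is not yet measured. It differs from compound 2 by hydrogen in place of methyl on an oxygen on an aromatic ring. Compound 1 also carries the hydroxy group but is otherwise different from compound 3, so its value gives no direct reading of this change. Among the compounds with values here, with no matching step in hand, the expectation is a step of small size in this assay, most likely within the scatter, in either direction. The estimated step from compound 2 to compound 3 is a 1.2-fold higher number from compound 2 to compound 3 (0.09 log units; within the scatter). For compound 3 the expected value is 320 nM, with a range from 120 nM to 850 nM.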

Compound 3, concentration for 50% growth inhibition: 1830 nM
Beside the measured number, compound 3's estimate is 5.7-fold (0.76 log units) below it; measured number outside the range, above it.
By their numbers in this assay, from the lowest: compound 2; then compounds 1 and 3 (each within the scatter of the next).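

In this assay, going by these compounds alone, the change from methoxy to hydroxy, on an oxygen on an aromatic ring, gives a 7.1-fold higher number from compound 2 to compound 3 (0.85 log units; beyond the scatter) and is the only difference in this pair, so the methyl on this oxygen matters for growth inhibition with dimethylamino in place. With the hydroxy group held, dimethylamino in place of phenoxy gives a 1.1-fold higher number from compound 1 to compound 3 (0.03 log units; within the scatter) and so does not separate these two groups. Within this small set, the exchange on the oxygen moves the number, while the exchange of dimethylamino for phenoxy leaves it within the scatter. Nothing at hand gives a reason for the step from methoxy to hydroxy.

On these data alone, whether the methoxy to hydroxy step holds with phenoxy in place of dimethylamino stays open, as phenoxy appears here only with the hydroxy group. Also open, as far as these compounds go, is how a longer chain on this oxygen, such as ethoxy, or an amine in place of the hydroxy group would read.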